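This account rests on a few compounds, and the source may have more. Where it says the series, first, only, none or still open, it means among the compounds named here.

In a functional assay on MCF7 cells (Homo sapiens) for antiproliferative activity, read by sulforhodamine B assay, with a stated time of 48 h (on this read-out lower numbers stand for stronger inhibition and higher numbers for weaker inhibition), compound 1 `Cc1ccc2c(c1)/C(=N/O)C(=O)N2CCCCCCC(=O)NO` gives 1190 nM and compound 2 `CO/N=C1/C(=O)N(CCCCCCC(=O)NO)c2ccccc21` gives 1710 nM. These two numbers lie within the usual scatter of repeated measurements, so compound 2 stands level with compound 1 and neither can be ranked above the other. Compound 3 `CO/N=C1/C(=O)N(CCCCCCC(=O)NO)c2ccc(Cl)cc21` is compound 2 with a single alteration: chloro in place of hydrogen on an aromatic carbon. In words, this is chloro in place of hydrogen on an aromatic carbon. Among the measured compounds shown here, no two measured compounds here differ in one place only, so the data give no direct measure of how far such a swap moves the number. For the measured compounds named here, the only guide is the narrow spread so far, with compound 2 at 1710 nM as the starting point. A large jump therefore seems unlikely for so small an alteration, though the direction remains a tentative call. The expected step is a 1.3-fold lower number from compound 2 to compound 3 (0.12 log units; within the scatter), a small move towards stronger inhibition that may well stay within the scatter. For compound 3 the estimated value is 1300 nM, with an expected range from 500 nM to 3200 nM.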

Compound 3, half-maximal inhibitory concentration: 1560 nM
Compound 3: the middle estimate sits 1.2-fold (0.08 log units) below what was measured, within the range that was stated.
By their numbers in this assay, from the lowest: compounds 1, 3 and 2 (each within the scatter of the next).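

In this assay, among the compounds shown here, chloro in place of hydrogen on an aromatic carbon gives a 1.1-fold lower number from compound 2 to compound 3 (0.04 log units; within the scatter), and this pair is the first here to differ in one place only, so it offers the first direct reading of a swap on the core. The position lies on the six-membered aromatic ring of carbon only, meta to a fused ring and para to a fused ring, and at this position one chlorine atom can stand where a hydrogen stood while the two compounds remain level within the usual scatter of repeated measurements. Nothing available here explains why the two compounds stand level.

Going by these compounds, one pair at one position cannot show whether this tolerance extends to other groups, so it remains open how an amine, a carboxylic acid or a methoxy group would read at the same carbon. On these data alone, it is equally open whether chloro on another carbon of that ring would give a similar result, and whether a longer chain ending in the same hydroxamic acid would leave this reading intact.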